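Chlorophenyl to pyridyl at the end of the enone chain

The source may report more compounds than this note shows. Statements on the series, on what has been measured and on what is new or still open speak of the compounds shown alone.

Measured so far:
Compound 1, `O=C(/C=C/c1ccc(Cl)cc1)C[C@@H]1O[C@H](CO)[C@@H](O)[C@H](O)[C@H]1O`: -5.97%
Compound 2, `O=C(/C=C/c1ccc(Cl)cc1)C[C@@H]1OC[C@@H](O)[C@H](O)[C@H]1O`: -8.3%

Both compounds were tested in an assay on isolated protein for inhibition of lysosomal alpha-glucosidase (Rattus norvegicus), tested at 100 uM; a higher number here means more inhibition at the concentration tested (going by the name of the read-out), a lower number less inhibition. Compound 1 gives -5.97%, the higher of the two numbers shown, but compound 2 gives -8.3%, and the step of a number 2.3 percentage points lower from compound 1 to compound 2 (within the scatter) is within the scatter, so the two cannot be told apart. Both numbers lie close to zero, meaning neither compound noticeably inhibits the enzyme at the concentration tested.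

Compound 3, `O=C(/C=C/c1cccnc1)C[C@@H]1O[C@H](CO)[C@@H](O)[C@H](O)[C@H]1O`, has not been measured yet. It differs from compound 1 in one place: pyridin-3-yl in place of 4-chlorophenyl on a double-bonded chain carbon bound to a double-bonded chain carbon. Among the compounds with values here, the only measured step concerns another part of the molecule, the hydroxymethyl on a saturated ring carbon, and it was small: a number 2.3 percentage points lower from compound 1 to compound 2 (within the scatter). Within the data shown here, no measured step touches the aromatic ring at the end of the chain, so nothing in the data suggests that exchanging it would move the read-out. With both measured compounds near zero, compound 3 is expected to stay near zero as well, a step of a number 2 percentage points higher from compound 1 to compound 3 (within the scatter). The estimate for compound 3 in this assay is -4%, with a range from -15% to 8%.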

Compound 3, a percentage reported as inhibition, at one concentration (the size of the read-out at that concentration, not a potency): -35.4%
Estimate against measurement, compound 3: 31.4 percentage points above; the whole stated range lies above it.
By their numbers in this assay, from the lowest: compound 3; then compounds 2 and 1 (each within the scatter of the next).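

In this assay the aromatic ring at the end of the enone chain turns out to matter, something the change of hydroxymethyl on the saturated ring carbon could not show. Pyridin-3-yl in place of 4-chlorophenyl on a double-bonded chain carbon bound to a double-bonded chain carbon gives a number 29.4 percentage points lower from compound 1 to compound 3 (beyond the scatter) and so moves the read-out beyond the scatter, but in the direction of a lower number, further below zero. Nothing measured here accounts for why the read-out moves this way.

Compound 3 loses the chlorine and brings in a ring nitrogen in a single change, so the compounds shown cannot say which of the two goes with the lower number. Going by these compounds, a plain phenyl ring at the same place would separate the two, and whether any group at the end of the chain, such as an amine on the ring, can push the number above zero also stays open.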